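This account rests on a few compounds, and the source may have more. Where it says the series, first, only, none or still open, it means among the compounds named here.

In a functional assay on MCF7 cells (Homo sapiens) for antiproliferative activity, read by MTT assay, with a stated time of 72 h (on this read-out higher numbers stand for weaker inhibition and lower numbers for stronger inhibition), compound 1 `COc1cc(-c2ncnn2-c2cccc(F)c2)cc(OC)c1OC` gives > 10000 nM, which is a limit of the assay and not a number. Compound 3 `COc1cc(-n2ncnc2-c2ccc(Cl)c(Cl)c2)cc(OC)c1OC` gives > 10000 nM, which is also a limit. Going by the values given here, compound 2 `COc1cc(-n2ncnc2-c2ccc(C)cc2)cc(OC)c1OC` gives 540 nM, the only true number so far. Compound 4 `COc1ccc(-n2ncnc2-c2cc(OC)c(OC)c(OC)c2)cc1` keeps the core of compound 1 and changes one group: 4-methoxyphenyl in place of 3-fluorophenyl on an aromatic nitrogen. Among the compounds with values here, the one measured step, an at least 18-fold higher number from compound 2 to compound 3 (1.26 log units; beyond the scatter), was large, but it changed a group on an aromatic carbon, not on an aromatic nitrogen. It bears only loosely here, showing that a single swap can matter greatly. A move towards lower numbers is expected, with an estimated step of an at least 6.6-fold lower number from compound 1 to compound 4 (0.82 log units; beyond the scatter). For compound 4 the estimate is 1500 nM, with an expected range from 100 nM to 10000 nM.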

Compound 4, half-maximal inhibitory concentration: 7400 nM
Compound 4: the middle estimate sits 4.9-fold (0.69 log units) below what was measured, and the stated range covers the measured number.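

On the aromatic nitrogen of the shared core, 4-methoxyphenyl gives a true number in this assay, the first for this arrangement of the core, since compound 4 gives 7400 nM. Putting it in place of 3-fluorophenyl brings an at least 1.3-fold lower number from compound 1 to compound 4 (0.13 log units; that floor lies within the scatter). The real size of this step stays unknown because compound 1 sits at a limit: the limit of > 10000 nM in this assay, at which 2 of the 4 values shown sit.

From the compounds shown here alone, it remains open whether any gain comes from the methoxy group itself or from its place on the phenyl ring. Going by these compounds, how an amine or a carboxylic acid on that ring would read also remains open.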